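This account rests on a few compounds, and the source may have more. Where it says the series, first, only, none or still open, it means among the compounds named here.

Measured so far:
compound 1 `O=C(Nc1cccc(-n2cc(-c3ccncc3)c(-c3cc(O)cc(Cl)c3)n2)c1)Nc1ccc(Cl)c(Cl)c1`: -55%
compound 2 `COc1cc(Cl)cc(-c2nn(-c3cccc(NC(=O)Nc4cc(C(F)(F)F)cc(C(F)(F)F)c4)c3)cc2-c2ccncc2)c1`: -70%

Both numbers come from a functional assay on HCC 2998 cells (Homo sapiens) for inhibition, read by sulforhodamine B assay, with a stated time of 48 h, tested at 100 uM; a lower number here means a stronger effect, a higher number a weaker effect of the compound at the concentration tested. Compound 1 stands highest of the two numbers; its nearest neighbour is compound 2, whose number lies lower by a margin beyond the usual scatter. For the measured compounds named here, no step between the two measured compounds that differ in one place is available, so the two values can only be read side by side.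

Compound 3 `COc1cc(Cl)cc(-c2nn(-c3cccc(NC(=O)Nc4ccc(Cl)c(Cl)c4)c3)cc2-c2ccncc2)c1` is not yet measured. It differs from compound 1 in one place: methyl in place of hydrogen on an oxygen on an aromatic ring — hydroxy to methoxy, 3-chloro-5-hydroxyphenyl to 3-chloro-5-methoxyphenyl.

Going by the values given here, compound 2 also carries the methoxy, but differs from compound 1 in further places, so no measured step isolates this change. For compound 3 the step of a number 5 percentage points lower from compound 1 to compound 3 (within the scatter) is expected to be small in this assay, if anything towards a lower number, and may fall within the scatter. Compound 3 is estimated at -60%, with a range from -85% to -35%.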

Compound 3, a percentage reported as activity, at one concentration (the size of the read-out at that concentration, not a potency): -7%
Compound 3: the middle estimate sits 53 percentage points below what was measured; the measured number lies above the stated range.
By their numbers in this assay, from the lowest: compound 2; then compound 1; then compound 3.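

The methyl on the oxygen is far from a neutral change: in this assay the step is a number 48 percentage points higher from compound 1 to compound 3 (beyond the scatter) and marks this hydroxy position as highly sensitive within the core of compound 1. Methoxy alone does not fix a weak read-out, since compound 2 also carries it and gives -70% while compound 3 gives -7% and the two differ only in the aryl group on the urea. No measurement at hand bears on the origin of this step.

On these data alone, what an amine, a fluorine or an ethoxy group would give in place of the hydroxy remains open. Also open, as far as these compounds go, is whether the hydroxy to methoxy step keeps its size with the aryl group of compound 2 in place, and the single tested concentration says nothing about potency.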